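Swapping cyclohexyl for a pyrazolylmethyl group

The source may hold more compounds than are shown below. What is called first, only, known or untested is meant among the compounds shown, and "the series" means these compounds.

Measured in an ADME assay on Caco-2 cells (Homo sapiens) for permeability, read by LC-MS, in the apical to basolateral direction, with a stated time of 60 min, at pH 6.5; a lower number here means that the compound crosses the layer more slowly, a higher number that the compound crosses the layer faster:
- compound 1 `CC(C)(C)[C@@H](O)C(=O)N1C[C@@H]2C[C@@H]2[C@H]1C(=O)NCc1cc(Cl)ccc1-n1cnnn1` gives 17 10^-6 cm/s
- compound 2 `O=C(NCc1cc(Cl)ccc1-n1cnnn1)[C@@H]1[C@H]2C[C@H]2CN1C(=O)[C@H](O)c1ccccc1` gives 12 10^-6 cm/s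
- compound 3 `O=C(NCc1cc(Cl)ccc1-n1cnnn1)[C@@H]1[C@H]2C[C@H]2CN1C(=O)[C@H](O)C1CCCCC1` gives 25 10^-6 cm/s

Compound 3 sits level with compound 1 at the top of this small set: a 1.5-fold higher number from compound 1 to compound 3 (0.17 log units; within the scatter) stays within the scatter, while a 2.1-fold higher number from compound 2 to compound 3 (0.32 log units; beyond the scatter) lies just beyond it.

Compound 4 `O=C(NCc1cc(Cl)ccc1-n1cnnn1)[C@@H]1[C@H]2C[C@H]2CN1C(=O)[C@H](O)Cn1cccn1` carries (1H-pyrazol-1-yl)methyl in place of cyclohexyl on a saturated chain carbon bound to a carbonyl carbon and an oxygen on a saturated carbon and is otherwise unchanged.

All three measured steps concern this same place, and all are small. None of them involves a group with hetero atoms, so the guidance is limited. The closest is a 2.1-fold higher number from compound 2 to compound 3 (0.32 log units; beyond the scatter), which links cyclohexyl to an aromatic ring, read here in reverse. The expected change is a 2.5-fold lower number from compound 3 to compound 4 (0.40 log units; beyond the scatter) in this assay, a lowering of about that size or a little more. For compound 4 the estimate is 10 10^-6 cm/s, with an expected range from 4 10^-6 cm/s to 22 10^-6 cm/s for the measurement.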

Compound 4, apparent permeability: 0.31 10^-6 cm/s
Compound 4: the middle estimate sits 32-fold (1.51 log units) above what was measured, outside the stated range (below it).
By their numbers in this assay, from the lowest: compound 4; then compounds 2, 1 and 3 (each within the scatter of the next, the first and the last beyond it).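

At this place, on a saturated chain carbon bound to a carbonyl carbon and an oxygen on a saturated carbon, tert-butyl, phenyl and cyclohexyl gave numbers close together, but (1H-pyrazol-1-yl)methyl stands far from all three in this assay (an 81-fold lower number from compound 3 to compound 4 (1.91 log units; beyond the scatter); a 39-fold lower number from compound 2 to compound 4 (1.59 log units; beyond the scatter); a 55-fold lower number from compound 1 to compound 4 (1.74 log units; beyond the scatter)). The position is therefore far from indifferent to the group it carries, and a matching count of heavy atoms, shared by cyclohexyl and (1H-pyrazol-1-yl)methyl, does not keep the number in place. Nothing available here gives a reason for this large drop.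

The compounds shown do not separate the part played by the pyrazole ring from that of its connecting carbon. A benzyl group would test the connecting carbon without the ring nitrogens, while a simple amine would show how another nitrogen-bearing group behaves here.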